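The compounds below may be only part of what the source reports. "The series", "measured", "known", "first", "only" and "open" are said of these compounds alone.

Compound 1, `Oc1ncnc2c1ncn2C[C@@H]1C[C@H](O)c2ccccc21`, in an ADME assay on L1210/0 cells (Mus musculus) for cytotoxicity, with a stated time of 48 h (a higher number here means a weaker inhibitor, a lower number a stronger inhibitor), gives only a limit, > 200000 nM.
Compound 2, `O[C@H]1C[C@@H](Cn2cnc3c(Cl)ncnc32)c2ccccc21`, in this assay gives only a limit, > 200000 nM.
Compound 3, `Nc1nc2c(nc(Cl)n2COCCO)c(=O)[nH]1`, in this assay gives only a limit, > 200000 nM.

The change from compound 2 to compound 1 is hydroxy in place of chloro on an aromatic carbon. Its step is a step that the two limits leave unreadable from compound 2 to compound 1, since both values sit at the limit of > 200000 nM in this assay, at which 3 of the 3 values shown sit. The difference between the core of compound 2 and the core of compound 3 is not broken down here.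

Compound 4, `Nc1nc2c(nc(O)n2COCCO)c(=O)[nH]1`, has not yet been measured. It differs from compound 3 by hydroxy in place of chloro on an aromatic carbon. This is the same kind of change as that from compound 2 to compound 1, but not the same: in compound 1 the place is on a six-membered aromatic ring with 2 nitrogen, next to the ring nitrogen, ortho to a fused ring, meta to a fused ring and opposite the ring nitrogen, whereas in compound 4 it is on a five-membered aromatic ring with 2 nitrogen, between two ring nitrogen atoms, next to the ring atom that bears a (2-hydroxyethoxy)methyl group.

In this assay the step from compound 3 to compound 4 is expected to be a step that the limit leaves unreadable from compound 3 to compound 4, resting on compound 3 having given only a limit and on the earlier step being unreadable. Compound 4 is therefore expected to give about 300000 nM, most likely again only a limit, within 100000 nM to 1000000 nM.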

Compound 4, half-maximal inhibitory concentration: > 200000 nM
Compound 4: no number, only a limit; the forecaster's own chance of this, stated with the estimate: 90%; the middle value lies beyond the limit too.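

No new step can be read from compound 3 to compound 4, since each of the two gives only a limit: the limit of > 200000 nM in this assay, at which 4 of the 4 values shown sit.

The compounds shown leave open whether hydroxy in place of chloro on an aromatic carbon changes the half-maximal inhibitory concentration on either core, and how the four compounds rank in this assay.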